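Hydroxy to methoxy steps in a series sitting at the assay limit

A few compounds are considered here, and "the series" means these few. Any claim that something is new, unique, unknown or untested is made for them only; others in the source may bear on it.

Compound 1 `COc1cc2oc(/C=C/[S+](C)[O-])cc(=O)c2cc1O`, compound 2 `COc1cc2oc(/C=C/[S+](C)[O-])cc(=O)c2cc1OC` and compound 3 `C[S+]([O-])/C=C/c1cc(=O)c2cc(O)ccc2o1` were run in a functional assay on A549 cells (Homo sapiens) for inhibition, with a stated time of 48 h; on this read-out lower numbers stand for stronger inhibition and higher numbers for weaker inhibition. Compound 1 gives > 10000 nM, which is a limit of the assay and not a number. Compound 2 gives > 10000 nM, also a limit. Compound 3 gives > 10000 nM, again a limit. The change from compound 1 to compound 2 is methyl in place of hydrogen on an oxygen on an aromatic ring; its step that the two limits leave unreadable from compound 1 to compound 2 cannot be read because of the limit of > 10000 nM in this assay, at which 3 of the 3 values shown sit. The cores of compound 1 and compound 3 differ by hydrogen in place of methoxy on an aromatic carbon. Compound 4 `COc1ccc2oc(/C=C/[S+](C)[O-])cc(=O)c2c1` is not yet measured in this assay; it differs from compound 3 by methyl in place of hydrogen on an oxygen on an aromatic ring, the same change as from compound 1 to compound 2, at a place described in identical terms. The expected step is a step that the limit leaves unreadable from compound 3 to compound 4, resting on the unreadable step that the two limits leave unreadable from compound 1 to compound 2 and on the limit (the limit of > 10000 nM in this assay, at which 3 of the 3 values shown sit). Compound 4 is therefore expected to give about 20000 nM, within a range from 8000 nM to 60000 nM, most probably reported again only as a limit.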

Compound 4, half-maximal inhibitory concentration: 9000 nM
Beside the measured number, compound 4's estimate is 2.2-fold (0.35 log units) above it, and the stated range covers the measured number.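

In this assay hydroxy to methoxy on the core of compound 3 gives an at least 1.1-fold lower number from compound 3 to compound 4 (0.04 log units; that floor lies within the scatter), so only a floor is known, and it shows no change beyond the scatter. The same change on the core of compound 1 has no readable size, and the other steps between two limits cannot be read either, so the transfer of this change from one core to the other is neither confirmed nor refuted, because the values sit at a ceiling: the limit of > 10000 nM in this assay, at which 3 of the 4 values shown sit. Hydrogen in place of methoxy on an aromatic carbon, with the methoxy from the hydroxy to methoxy change kept, gives an at least 1.1-fold lower number from compound 2 to compound 4 (0.04 log units; that floor lies within the scatter), again a floor within the scatter and no evidence that either core is favoured.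

Still open, from the compounds shown here alone, is how far compound 1, compound 2 and compound 3 lie beyond the limit in this assay, and so whether any of these steps has a real size. Also open, going by these compounds, is whether a longer chain on that oxygen, or an amine or a carboxylic acid in place of the hydroxy, would give values that can be read.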